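The compounds below may be only part of what the source reports. "The series", "measured", "known", "first", "only" and "open" are said of these compounds alone.

Series notes. Compound 1 `CC(=O)OC(C)n1cnc2c(Cl)nc(N)nc21` carries amino and chloro on the shared core. In a functional assay on L1210 cells (Mus musculus) for inhibition (on this read-out lower numbers stand for stronger inhibition and higher numbers for weaker inhibition), compound 1 returns only a limit, > 500000 nM; this is the cut-off described by the limit of > 500000 nM in this assay, at which 1 of the 3 values shown sits, not a number. Compound 2 `CC(=O)OC(C)n1cnc2c(Cl)nc(F)nc21`, with fluoro in place of amino, gives 37000 nM in this assay, a step of an at least 13-fold lower number from compound 1 to compound 2 (1.13 log units; beyond the scatter). Compound 3 `CC(=O)OC(C)n1cnc2c(S)nc(N)nc21`, with sulfanyl in place of chloro, gives 128000 nM in this assay, a step of an at least 3.9-fold lower number from compound 1 to compound 3 (0.59 log units; beyond the scatter). Among the two numbers in hand, compound 3 stands highest, with compound 2 the nearest and lower.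

Compound 4 `CC(=O)OC(C)n1cnc2c(S)nc(F)nc21` is the next entry in this assay and is still to be measured. It differs from compound 3 in one place: fluoro in place of amino on an aromatic carbon. The same change is already measured once, on the chloro-bearing core, as the step from compound 1 to compound 2, where it gave an at least 13-fold lower number from compound 1 to compound 2 (1.13 log units; beyond the scatter), a large drop, though from a limit. On that basis a large downward step is expected for compound 4 in this assay, of about a 13-fold lower number from compound 3 to compound 4 (1.11 log units; beyond the scatter). Compound 4 is accordingly estimated at 10000 nM in this assay, within a range of 3000 nM to 40000 nM.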

Compound 4, half-maximal inhibitory concentration: 226000 nM
Compound 4: the middle estimate sits 23-fold (1.35 log units) below what was measured; measured number outside the range, above it.
By their numbers in this assay, from the lowest: compound 2; then compounds 3 and 4 (each within the scatter of the next). At a limit, above all of these: compound 1.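

On the sulfanyl-bearing core, fluoro in place of amino at the carbon between two ring nitrogen atoms gives a 1.8-fold higher number from compound 3 to compound 4 (0.25 log units; within the scatter) in this assay, so the large fall seen on the chloro-bearing core does not carry over to this core: the same change on two cores in this assay, an at least 13-fold lower number (1.13 log units; beyond the scatter) from compound 1 to compound 2 and a 1.8-fold higher number (0.25 log units; within the scatter) from compound 3 to compound 4, at least 23-fold (1.37 log units) apart, beyond the scatter of two such steps. The exchange of chloro for sulfanyl also depends on the group at this position, since it gives a 6.1-fold higher number from compound 2 to compound 4 (0.79 log units; beyond the scatter) with fluoro present, opposite in direction to the step read with amino present: the same change on two cores in this assay, an at least 3.9-fold lower number (0.59 log units; beyond the scatter) from compound 1 to compound 3 and a 6.1-fold higher number (0.79 log units; beyond the scatter) from compound 2 to compound 4, at least 23-fold (1.37 log units) apart, beyond the scatter of two such steps. The two changes therefore do not add up across these four compounds, and in this assay compound 2, at 37000 nM, holds the lowest number only with fluoro and chloro together.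

Compound 1 gives only a limit, > 500000 nM, which leaves the true size of both steps that start from it open: the limit of > 500000 nM in this assay, at which 1 of the 4 values shown sits. From the compounds shown here alone, whether this dependence on the partner group extends to a hydroxyl or a methylamino group at the position between two ring nitrogen atoms, or to a methylthio group in place of sulfanyl, also stays open.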